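This account rests on a few compounds, and the source may have more. Where it says the series, first, only, none or still open, it means among the compounds named here.

Within the data shown here, compound 1, whose structure is `CCCC[S+]([O-])c1sc2nc(-c3nccs3)cc(-c3cccc(CO)c3)c2c1N`, is the only compound of this set with a numerical result. In an assay for inhibition of 15-hydroxyprostaglandin dehydrogenase [NAD(+)] (Homo sapiens), read by fluorescence, with a stated time of 15 min, in the presence of a further agent that is not named here (a lower number here means a stronger inhibitor, a higher number a weaker inhibitor), compound 1 gives 4.3 nM. The other measured compound, compound 2, has the structure `CCOC(=O)c1sc2nc(-c3cccs3)cc(-c3ccccc3)c2c1N`. Among the measured compounds shown here, for compound 2 the result in this assay is a limit, > 7500 nM, and not a number, so that no step between the two measured compounds can be stated; the limit is recorded as the limit of > 7500 nM in this assay, at which 1 of the 2 values shown sits. Compound 1 therefore stands alone as the anchor for any expectation.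

The unmeasured compound 3 has the structure `CCCC[S+]([O-])c1sc2nc(-c3nccs3)cc(-c3ccc(CN)cc3)c2c1N`. It differs from compound 1 in one place: 4-(aminomethyl)phenyl in place of 3-(hydroxymethyl)phenyl on an aromatic carbon. For the measured compounds named here, no step between measured compounds has been recorded. The size of this change therefore has to be guessed. The change keeps the same count of heavy atoms, donors and acceptors on the aryl group, and the expectation is a small loss, near the edge of the usual scatter, so the step from compound 1 to compound 3 in this assay is estimated as a 2.1-fold higher number from compound 1 to compound 3 (0.32 log units; beyond the scatter). Compound 3 is accordingly expected to give 9 nM, with a range from 2.5 nM to 35 nM.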

Compound 3, half-maximal inhibitory concentration: 11.5 nM
Beside the measured number, compound 3's estimate is 1.3-fold (0.11 log units) below it; low and high end bracket the measured number.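

Among these compounds, the only measured step at this aromatic carbon, opposite the ring nitrogen, is modest but beyond the scatter: in this assay there is a 2.7-fold higher number from compound 1 to compound 3 (0.43 log units; beyond the scatter). It shows that this position accepts 4-(aminomethyl)phenyl in place of 3-(hydroxymethyl)phenyl without a collapse in inhibition, as compound 3 still gives 11.5 nM with the same count of heavy atoms, donors and acceptors on the aryl group. Nothing measured here accounts for the size of this step.

The compounds shown leave open whether the step follows from replacing oxygen with nitrogen or from moving the side chain to another carbon of the phenyl ring, since both differences arrive together in this single comparison. They also leave open how a carboxylic acid or a longer aminoethyl chain on the same phenyl ring would read in this assay, and whether the small difference seen here would hold for such groups.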